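The source may report more compounds than this note shows. Statements on the series, on what has been measured and on what is new or still open speak of the compounds shown alone.

Measured in a functional assay on CCRF-CEM cells (Homo sapiens) for cytotoxicity; on this read-out lower numbers stand for higher toxicity in this test and higher numbers for lower toxicity in this test:
- Compound 1 `CCCCCC(=O)Nc1nc(N)nc2c1ncn2[C@H]1CO[C@@H](CO)O1`: > 100000 nM, a limit of the assay
- Compound 2 `CCCCCCCC(=O)Nc1nc(N)nc2c1ncn2[C@H]1CO[C@@H](CO)O1`: > 100000 nM, a limit of the assay
- Compound 3 `CCCCCCCCCCCC(=O)Nc1nc(N)nc2c1ncn2[C@H]1CO[C@@H](CO)O1`: 13000 nM

Among the compounds with values here, compound 3 holds the only actual number in this short series. Compound 1 and compound 2 both sit at the limit of > 100000 nM in this assay, at which 2 of the 3 values shown sit.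

The next member is compound 4 `CCCCCCCCCCCCCCCC(=O)Nc1nc(N)nc2c1ncn2[C@H]1CO[C@@H](CO)O1`, and the change leading to it is butyl in place of hydrogen on a saturated chain carbon, ten or more bonds along the chain from a carbonyl carbon. This lengthens the same chain that already varies across the measured compounds.

Within the data shown here, two measured steps bear on it, and both are of the same kind. The first is an at least 7.6-fold lower number from compound 1 to compound 3 (0.88 log units; beyond the scatter). The second is an at least 7.6-fold lower number from compound 2 to compound 3 (0.88 log units; beyond the scatter). The remaining step, a step that the two limits leave unreadable from compound 1 to compound 2, gives no size to work with. Among these three compounds, only the longest chain gives a number, and none goes against that trend.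

A further extension therefore points towards a lower number in this assay. However, only one real number anchors the series, so the size is poorly fixed and a step within the scatter cannot be ruled out. The expected change is a 1.9-fold lower number from compound 3 to compound 4 (0.27 log units; within the scatter). For compound 4 the estimated value is 7000 nM, with an expected range of 1500 nM to 40000 nM.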

Compound 4, half-maximal cytotoxic concentration: > 100000 nM
Compound 4 was reported as a limit; the forecaster's own chance of this, stated with the estimate: 20%; middle value at least 14-fold (1.15 log units) from the limit.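

In this assay, the butyl added on a saturated chain carbon reverses the direction seen so far, giving an at least 7.6-fold higher number from compound 3 to compound 4 (0.88 log units; beyond the scatter). Compound 4 gives > 100000 nM, which is a limit of the assay. Lengthening this chain therefore does not keep lowering the number, and compound 4 goes against the trend that compound 1, compound 2 and compound 3 suggested, leaving compound 3 as the only member of the series with an actual number: the limit of > 100000 nM in this assay, at which 3 of the 4 values shown sit.

As far as these compounds go, the steps from compound 1 and from compound 2 to compound 4 cannot be read, as both ends of each are limits, so how far these three compounds lie from one another stays unknown. Also open, from the compounds shown here alone, are how the read-out behaves for chains of a length between those of compound 3 and compound 4, and whether a chain carrying an amine or a carboxylic acid would follow the same course.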